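Swapping an aryl group on the pyrazole ring of urea TRPV1 antagonists

The source may report more compounds than this note shows. Statements on the series, on what has been measured and on what is new or still open speak of the compounds shown alone.

Measured compounds:
compound 1, `Cn1ncc2c(NC(=O)NCc3cc(C(F)(F)F)nn3-c3ccc(C(C)(C)C)cc3)cccc21`, 13.2 nM
compound 2, `Cn1ncc2c(NC(=O)NCc3cc(C(F)(F)F)nn3-c3ccc(F)c(F)c3)cccc21`, 4.9 nM
compound 3, `CC(C)(C)c1ccc(-n2nc(C(C)(C)C)cc2CNC(=O)Nc2cccc3[nH]ncc23)cc1`, 40 nM

Three compounds were tested in an assay on CHO-K1 cells for antagonist activity at transient receptor potential cation channel subfamily V member 1 (Homo sapiens), read by FLIPR and calcium flux, with a stated time of 6 min; on this read-out lower numbers stand for stronger inhibition and higher numbers for weaker inhibition. Compound 1, with the structure `Cn1ncc2c(NC(=O)NCc3cc(C(F)(F)F)nn3-c3ccc(C(C)(C)C)cc3)cccc21`, gives 13.2 nM in this assay. Compound 2, with the structure `Cn1ncc2c(NC(=O)NCc3cc(C(F)(F)F)nn3-c3ccc(F)c(F)c3)cccc21`, gives 4.9 nM. Compound 3, with the structure `CC(C)(C)c1ccc(-n2nc(C(C)(C)C)cc2CNC(=O)Nc2cccc3[nH]ncc23)cc1`, gives 40 nM, the highest number of the three, and its steps to compound 1 and to compound 2 both lie beyond the scatter.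

The change from compound 1 to compound 2 is 3,4-difluorophenyl in place of 4-(tert-butyl)phenyl on an aromatic nitrogen. It gave a 2.7-fold lower number from compound 1 to compound 2 (0.43 log units; beyond the scatter).

Compound 4, with the structure `CC(C)(C)c1cc(CNC(=O)Nc2cccc3[nH]ncc23)n(-c2ccc(F)c(F)c2)n1`, has not yet been measured in this assay. It is related to compound 3 by 3,4-difluorophenyl in place of 4-(tert-butyl)phenyl on an aromatic nitrogen. This is the same kind of change as that from compound 1 to compound 2, but the surroundings are not identical: in compound 1 the place is two ring bonds from the ring atom that bears a trifluoromethyl group, whereas in compound 3 it is two ring bonds from the ring atom that bears a tert-butyl group. The difference between the core of compound 1 and the core of compound 3 is not broken down here.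

Within the data shown here, since the one measured example of this change lowered the number, compound 4 is expected to show a step of about a 2.7-fold lower number from compound 3 to compound 4 (0.43 log units; beyond the scatter), resting on the step from compound 1 to compound 2, with some uncertainty because the neighbouring group differs. The estimate for compound 4 is therefore 15 nM, with a range from 5 nM to 45 nM.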

Compound 4, inhibition constant: 0.5 nM
The estimate for compound 4 lay 30-fold (1.48 log units) above the measured number, and the stated range ends above it.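

In this assay, 3,4-difluorophenyl in place of 4-(tert-butyl)phenyl on an aromatic nitrogen lowered the number on both cores, so the direction of the change carried over from one core to the other, but its size did not: the same change on two cores in this assay, a 2.7-fold lower number (0.43 log units; beyond the scatter) from compound 1 to compound 2 and an 80-fold lower number (1.90 log units; beyond the scatter) from compound 3 to compound 4, 30-fold (1.47 log units) apart, beyond the scatter of two such steps. On the core of compound 3 the change gave an 80-fold lower number from compound 3 to compound 4 (1.90 log units; beyond the scatter), a large step, so the size of the step measured on the core of compound 1 did not serve as a guide to the size on the core of compound 3. Among these compounds, with only one pair on each core, these results do not show which part of the difference between the two cores goes with the larger step, nor whether the same direction would hold on any further core.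

The compounds shown leave open how other groups on that aromatic nitrogen, such as an unsubstituted phenyl or a 4-chlorophenyl, would behave on either core. They also leave open whether a cyclopropyl group in place of the tert-butyl group on the core of compound 3 would keep a step of this size.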